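A few compounds are considered here, and "the series" means these few. Any claim that something is new, unique, unknown or untested is made for them only; others in the source may bear on it.

Compound 1 `Oc1ccc(-c2cc(-c3ccc(F)cc3)cc(-c3ccccc3O)n2)cc1`: > 50000 nM (a limit)
Compound 2 `Oc1ccc(-c2cc(-c3ccccc3F)cc(-c3cccc(O)c3)n2)cc1`: 14300 nM

In a functional assay on HeLa cells (Homo sapiens) for inhibition (a lower number here means a stronger inhibitor, a higher number a weaker inhibitor), compound 1 reaches only the limit of the assay, > 50000 nM. For the measured compounds named here, compound 2 gives 14300 nM in this assay and is the only compound with a number rather than a limit; the other value sits at the limit of > 50000 nM in this assay, at which 1 of the 2 values shown sits.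

Compound 3 `Oc1ccc(-c2cc(-c3ccc(F)cc3)cc(-c3cccc(O)c3)n2)cc1` differs from compound 2 by 4-fluorophenyl in place of 2-fluorophenyl on an aromatic carbon. Going by the values given here, no step between two measured compounds shows what this change does here, so the expected step from compound 2 to compound 3 is small and uncertain, in either direction: a 1.0-fold higher number from compound 2 to compound 3 (0.02 log units; within the scatter). Compound 3 is therefore estimated at 15000 nM in this assay, with a range from 4000 nM to 60000 nM.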

Compound 3, half-maximal inhibitory concentration: 8080 nM
Estimate against measurement, compound 3: 1.9-fold (0.27 log units) above, within the range that was stated.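

In this assay, 4-fluorophenyl in place of 2-fluorophenyl, on the aromatic carbon opposite the ring nitrogen, stays within the scatter (a 1.8-fold lower number from compound 2 to compound 3 (0.25 log units; within the scatter)). The change from 2-hydroxyphenyl to 3-hydroxyphenyl, by contrast, goes beyond the scatter (an at least 6.1-fold lower number from compound 1 to compound 3 (0.79 log units; beyond the scatter)). Compound 1 stands at a limit, so this step gives only a lower bound on the change: the limit of > 50000 nM in this assay, at which 1 of the 3 values shown sits.

The compounds shown leave open how a plain phenyl or an aminophenyl group would read at the fluorophenyl position. They also leave open whether a carboxylic acid or an amine could take the place of either hydroxyl group.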